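The compounds below may be only part of what the source reports. "The series", "measured", "known", "first", "only" and "open" are said of these compounds alone.

In an ADME assay on microsomes from liver (Mus musculus) for metabolic stability, read by LC-MS, using NADPH, tested at 4.6 uM (a lower number here means that the compound disappears faster, a higher number that the compound lasts longer), compound 1 `O=C(NCCCCc1ccccc1)n1cc(-c2ccccc2)oc1=O` gives 0.667 h, compound 2 `COc1cccc(-c2cn(C(=O)NCCCCc3ccccc3)c(=O)o2)c1` gives 0.5 h and compound 3 `O=C(NCCCCc1ccccc1)n1cc(-c2ccccn2)oc1=O` gives 0.167 h, the lowest of the three numbers. Compound 4 `O=C(NCCCCc1ccccc1)n1cc(-c2ccncc2)oc1=O` is still unmeasured. It differs from compound 3 in one place, with pyridin-4-yl in place of pyridin-2-yl on an aromatic carbon.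

Among the compounds with values here, two measured steps bear on this change, both with pyridin-2-yl entering: a 4.0-fold lower number from compound 1 to compound 3 (0.60 log units; beyond the scatter) and a 3.0-fold lower number from compound 2 to compound 3 (0.48 log units; beyond the scatter). The third, a 1.3-fold lower number from compound 1 to compound 2 (0.13 log units; within the scatter), says little here. Within the data shown here, no other measured compound carries a pyridinyl group, so the data give no direct comparison of the two pyridinyl groups.

Compound 4 keeps a pyridinyl group, so its number is expected to stay closer to compound 3, at 0.167 h, than to compound 1, at 0.667 h, with only a slight lean upward in this assay. The expected change is a 1.8-fold higher number from compound 3 to compound 4 (0.25 log units; within the scatter). For compound 4 the estimate is 0.3 h, with an expected range of 0.13 h to 0.67 h.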

Compound 4, half-life: > 1 h
Compound 4 was reported as a limit (the forecaster's own chance of this, stated with the estimate: 5%); middle value at least 3.3-fold (0.52 log units) from the limit.
By their numbers in this assay, from the lowest: compound 3; then compounds 2 and 1 (each within the scatter of the next). At a limit, above all of these: compound 4.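

In this assay compound 4 gives > 1 h, which is a limit of the assay and not a number. Moving the ring nitrogen alone, with the same atoms joined differently, gives an at least 5.9-fold higher number from compound 3 to compound 4 (0.77 log units; beyond the scatter), so the short half-life seen with pyridin-2-yl does not extend to pyridinyl groups in general at this position, next to the ring oxygen. The remaining steps set only floors, an at least 2.0-fold higher number from compound 2 to compound 4 (0.30 log units; that floor lies within the scatter) and an at least 1.4-fold higher number from compound 1 to compound 4 (0.17 log units; that floor lies within the scatter), so pyridin-4-yl cannot yet be ranked firmly against 3-methoxyphenyl or phenyl here.

On these data alone, the true size of all three steps stays open while compound 4 rests on a limit. Also open, as far as these compounds go, is whether the result carries over to pyridin-3-yl, or to a pyridin-4-yl group bearing an amine.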